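Amide variation on the shared core: compound 3 to compound 4

This account rests on a few compounds, and the source may have more. Where it says the series, first, only, none or still open, it means among the compounds named here.

In a functional assay on Caco-2 cells (Homo sapiens), read by MTT assay, with a stated time of 48 h (a lower number here means a stronger inhibitor, a higher number a weaker inhibitor), compound 3 (`CCn1c(C(=O)N(CCC#N)CCC#N)ccc1C(CC)(CC)c1ccc(OCC(O)C(C)(C)C)c(C)c1`) gives 7100 nM, within the scatter of compound 1 (`CCOC(=O)CN(C)C(=O)c1ccc(C(CC)(CC)c2ccc(OCC(O)C(C)(C)C)c(C)c2)n1CC`) at 12200 nM. Within the data shown here, compound 2 (`CCn1c(C(=O)NCCN(C)C)ccc1C(CC)(CC)c1ccc(OCC(O)C(C)(C)C)c(C)c1`) gives 1300 nM, and only this compound stands apart from the others.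

Compound 4 (`CC[C@@H](C)[C@H](NC(=O)c1ccc(C(CC)(CC)c2ccc(OCC(O)C(C)(C)C)c(C)c2)n1CC)C(=O)O`) differs from compound 3 by a group of 9 heavy atoms (6 carbon, 1 nitrogen, 2 oxygen; no ring) in place of a group of 9 heavy atoms (6 carbon, 3 nitrogen; no ring), on a carbonyl carbon, with (1-carboxy-2-methylbutyl)amino entering on a carbonyl carbon.

Among the measured compounds shown here, three measured steps bear on this change. Two reach beyond the scatter, a 9.4-fold lower number from compound 1 to compound 2 (0.97 log units; beyond the scatter) and a 5.5-fold higher number from compound 2 to compound 3 (0.74 log units; beyond the scatter), and both involve compound 2. The third, a 1.7-fold lower number from compound 1 to compound 3 (0.24 log units; within the scatter), stays within it. The entering group has no counterpart among these compounds, so the estimate is loose. The step expected in this assay is a 1.1-fold higher number from compound 3 to compound 4 (0.05 log units; within the scatter), none beyond the scatter. Compound 4 is estimated at 8000 nM, with a range of 2500 nM to 25000 nM.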

Compound 4, half-maximal inhibitory concentration: 3400 nM
Compound 4: middle estimate off by 2.4-fold (0.37 log units), on the high side; measured number inside the range.
By their numbers in this assay, from the lowest: compound 2; then compound 4; then compounds 3 and 1 (each within the scatter of the next).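

In this assay, (1-carboxy-2-methylbutyl)amino on the carbonyl carbon gives a lower number than the nitrile-bearing group (a 2.1-fold lower number from compound 3 to compound 4 (0.32 log units; beyond the scatter)) and the ester-bearing group (a 3.6-fold lower number from compound 1 to compound 4 (0.55 log units; beyond the scatter)). It does not reach 2-(dimethylamino)ethyl (a 2.6-fold higher number from compound 2 to compound 4 (0.42 log units; beyond the scatter)), so compound 4 takes a middle place and compound 2 is no longer the only amide set apart from the rest. Nothing given here accounts for these differences.

From the compounds shown here alone, whether the carboxylic acid or the branched chain carries the change stays open. The methyl ester of the same group, or a primary amine on a longer chain, would bear on this.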